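A Trifluoromethyl Added to an Inactive Amide

The source may report more compounds than this note shows. Statements on the series, on what has been measured and on what is new or still open speak of the compounds shown alone.

Compound 2 `Cn1cc2c(Cl)nc(NC(=O)c3ccccc3)nc2n1` was tested in an assay on CHO cells for displacement of a labelled ligand from adenosine receptor A1 (Homo sapiens), read by scintillation counting, with a stated time of 3 h; a higher number here means a weaker inhibitor, a lower number a stronger inhibitor. In that assay compound 2 gives > 100000 nM, a limit of the assay rather than a number. Compound 1 `Cc1ccc(C(=O)Nc2nc(Cl)c3cn(C)nc3n2)cc1` carries a methyl group that compound 2 lacks. In this assay compound 1 gives > 100000 nM, again a limit. Two values sit at the limit of > 100000 nM in this assay, at which 2 of the 2 values shown sit, so the step that the two limits leave unreadable from compound 1 to compound 2 cannot be read. Compound 3 `Cn1cc2c(Cl)nc(NC(=O)c3ccc(C(F)(F)F)cc3)nc2n1` differs from compound 2 by trifluoromethyl in place of hydrogen on an aromatic carbon. No readable step bears on this change. Compound 3 is therefore expected to remain at the limit, an estimated 100000 nM (between 30000 nM and 400000 nM), meaning an expected step of a number no higher from compound 2 to compound 3 (the limit leaves the size open) in this assay.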

Compound 3, inhibition constant: > 100000 nM
Compound 3 ended at the assay's limit; the forecaster's own chance of this, stated with the estimate: 85%; the middle value lies on the limit itself.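

No step among compound 1, compound 2 and compound 3 can be read in this assay: the limit of > 100000 nM in this assay, at which 3 of the 3 values shown sit.

The compounds shown leave open which change to the shared core, if any, would give a number rather than a limit in this assay.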